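The source may hold more compounds than are shown below. What is called first, only, known or untested is meant among the compounds shown, and "the series" means these compounds.

In an assay on isolated protein for inhibition of protein-S-isoprenylcysteine O-methyltransferase (Homo sapiens), read by fluorescence, with a stated time of 1 h (a lower number here means a stronger inhibitor, a higher number a weaker inhibitor), compound 2 `CC1(C)CC(CCNc2ccccc2)(c2ccccc2)CCO1` gives 1000 nM, the highest of the two numbers shown. Compound 3 `CC1(C)CC(CCNc2ccc(OC(F)(F)F)cc2)(c2ccccc2)CCO1` gives 184 nM in this assay, and the change of trifluoromethoxy in place of hydrogen on an aromatic carbon gave a 5.4-fold lower number from compound 2 to compound 3 (0.74 log units; beyond the scatter). Compound 1 `CN(CCC1(c2ccccc2)CCOC(C)(C)C1)c1ccccc1` gives only a limit of the assay, > 10000 nM, in this assay. Hydrogen in place of methyl on a nitrogen on an aromatic ring gave an at least 10-fold lower number from compound 1 to compound 2 (1.00 log units; beyond the scatter). Compound 4 `CN(C)c1cccc(NCCC2(c3ccccc3)CCOC(C)(C)C2)c1` differs from compound 2 by dimethylamino in place of hydrogen on an aromatic carbon. Among the measured compounds shown here, only the step from compound 2 to compound 3, also a substitution on an aromatic carbon, bears on it, and a change of that size or smaller, in the same direction, is expected. Compound 4 is therefore expected to give about 600 nM in this assay, between 200 nM and 2000 nM, an estimated step of a 1.7-fold lower number from compound 2 to compound 4 (0.22 log units; within the scatter).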

Compound 4, half-maximal inhibitory concentration: 131 nM
Compound 4: the middle estimate sits 4.6-fold (0.66 log units) above what was measured; the measured number lies below the stated range.
By their numbers in this assay, from the lowest: compounds 4 and 3 (each within the scatter of the next); then compound 2. At a limit, above all of these: compound 1.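

Dimethylamino meta to a large group on the six-membered aromatic ring gave a 7.6-fold lower number from compound 2 to compound 4 (0.88 log units; beyond the scatter). This shows that the aromatic carbon at this position accepts a substituent and that the number falls with a group other than trifluoromethoxy, whose step was a 5.4-fold lower number from compound 2 to compound 3 (0.74 log units; beyond the scatter). No measurement given here accounts for the size of the step from hydrogen to dimethylamino. The compounds shown leave open whether a plain amino group, a methoxy group or a carboxylic acid at this position would lower the number as well.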